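Notes on the step from compound 3 to compound 4

The source may hold more compounds than are shown below. What is called first, only, known or untested is meant among the compounds shown, and "the series" means these compounds.

Compound 3 `COc1ccc2nc(C(=O)Nc3c(F)cc(-c4cccc(F)c4)cc3F)c(C)c(C(=O)O)c2c1` gives -0.68% in a functional assay on Hep 3B2 cells (Homo sapiens) for antiproliferative activity, read by MTT assay, with a stated time of 24 h, tested at 0.01 ug/mL; on this read-out lower numbers stand for a weaker effect and higher numbers for a stronger effect at the one concentration tested. Among the measured compounds shown here, of the three numbers measured so far it is the lowest, with compound 1 `Cc1c(C(=O)Nc2c(F)cc(-c3cccc(F)c3)cc2F)nc2ccc(C(F)(F)F)cc2c1O` at -0.33% and compound 2 `CCOc1ccc2nc(C(=O)Nc3c(F)cc(-c4cccc(F)c4)cc3F)c(C)c(C(=O)O)c2c1` at -0.12%; both gaps are within the scatter, so no order among the three is supported. For the measured compounds named here, the one step measured within the set, a number 0.6 percentage points lower from compound 2 to compound 3 (within the scatter), is within the scatter as well. Compound 4 `Cc1c(C(=O)Nc2c(F)cc(-c3cccc(F)c3)cc2F)nc2ccc(C(F)(F)F)cc2c1C(=O)O` differs from compound 3 by trifluoromethyl in place of methoxy on an aromatic carbon. Going by the values given here, no measured step bears directly on this change; compound 1 already carries the trifluoromethyl in place of the methoxy and shows a value within the scatter of compound 3, which is the only point of comparison available. With all three numbers within the scatter of one another, no step beyond the scatter is expected in this assay in either direction, and compound 4 is expected at -0.4% with a range from -8% to 8%. The step this implies, a number 0.3 percentage points higher from compound 3 to compound 4 (within the scatter), is estimated to lie within the scatter.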

Compound 4, a percentage reported as inhibition, at one concentration (the size of the read-out at that concentration, not a potency): 0.2%
Compound 4: the middle estimate sits 0.6 percentage points below what was measured; the range from low to high includes it.
By their numbers in this assay, from the lowest: compounds 3, 1, 2 and 4 (each within the scatter of the next).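

In this assay, trifluoromethyl in place of methoxy on this aromatic carbon gives a number 0.9 percentage points higher from compound 3 to compound 4 (within the scatter), and trifluoromethyl in place of ethoxy gives a number 0.3 percentage points higher from compound 2 to compound 4 (within the scatter), so with the carboxy kept, none of these three groups separates from the others at this position. The change at the second place, carboxy in place of hydroxy on an aromatic carbon with the trifluoromethyl kept, gives a number 0.5 percentage points higher from compound 1 to compound 4 (within the scatter), so this exchange also leaves the read-out within the scatter. Nothing available explains these results.

On these data alone, whether an amine or a longer alkoxy chain on this aromatic carbon would give a step beyond the scatter remains open. Also open, as far as these compounds go, is whether these four compounds would separate at a higher concentration.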